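This account rests on a few compounds, and the source may have more. Where it says the series, first, only, none or still open, it means among the compounds named here.

Within the data shown here, in a functional assay on K562 cells (Homo sapiens) for inhibition, read by trypan blue exclusion, with a stated time of 72 h (a higher number here means a weaker inhibitor, a lower number a stronger inhibitor), compound 3 (`Cc1ccc(S(=O)(=O)c2cc3cnc(Nc4cnc5[nH]ccc5c4)nc3n(C)c2=O)cc1`) gives 15000 nM, the highest number of the three measured so far, and compound 1 (`Cn1c(=O)c(S(=O)(=O)c2ccccc2)cc2cnc(Nc3cnc4[nH]ccc4c3)nc21`) gives 5000 nM. Compound 4 (`Cn1c(=O)c(S(=O)(=O)c2ccc(F)cc2F)cc2cnc(Nc3cnc4[nH]ccc4c3)nc21`) keeps the core of compound 3 and carries 2,4-difluorophenyl in place of 4-methylphenyl on a sulfonyl sulfur. Among the measured compounds shown here, only one measured step bears on this group: a 3.0-fold higher number from compound 1 to compound 3 (0.48 log units; beyond the scatter), a modest change beyond the scatter, with methyl in place of hydrogen on an aromatic carbon. Compound 4 also lacks that methyl, which points toward a lower number. For the measured compounds named here, compound 2 (`Cn1ccc2cc(Nc3ncc4cc(S(=O)(=O)c5ccc(F)cc5F)c(=O)n(C)c4n3)ccc21`) carries the same 2,4-difluorophenyl and gives 750 nM, but it differs from compound 4 elsewhere, and no measured step isolates the two fluorines. A modest move toward a stronger inhibitor is therefore expected in this assay. The expected change is a 3.8-fold lower number from compound 3 to compound 4 (0.57 log units; beyond the scatter). For compound 4 the estimated value is 4000 nM, with an expected range of 1200 nM to 12000 nM.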

Compound 4, half-maximal inhibitory concentration: 750 nM
Compound 4: the middle estimate sits 5.3-fold (0.73 log units) above what was measured; measured number outside the range, below it.
By their numbers in this assay, from the lowest: compounds 2 and 4 (each within the scatter of the next); then compound 1; then compound 3.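

In this assay, the aryl group on the sulfonyl sulfur proves a stronger lever on this core than the methyl step alone suggested: 2,4-difluorophenyl lowers the number both against 4-methylphenyl (a 20-fold lower number from compound 3 to compound 4 (1.30 log units; beyond the scatter)) and against phenyl (a 6.7-fold lower number from compound 1 to compound 4 (0.82 log units; beyond the scatter)). With 2,4-difluorophenyl held constant, exchanging the group on a nitrogen on an aromatic ring leaves the result unmoved (no change at the digits printed from compound 2 to compound 4 (within the scatter)), so at least these two groups on that nitrogen are interchangeable in this assay. No evidence at hand bears on why the sulfonyl change has this size.

The separate contributions of the two fluorines remain open, as 4-fluorophenyl and 2-fluorophenyl do not appear among the compounds shown. Also open, as far as these compounds go, is whether a non-aromatic group on the sulfonyl sulfur, such as cyclopropyl or a short alkyl chain, would keep the lower number.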